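The source may report more compounds than this note shows. Statements on the series, on what has been measured and on what is new or still open speak of the compounds shown alone.

Measured so far:

Compound 1, `COCc1ccc(-c2ccc3nnc(C(N)=O)c(N[C@@H](C)c4nn(C)cc4C)c3c2)cn1`: 18 uL/min
Compound 2, `C[C@H](Nc1c(C(N)=O)nnc2ccc(-c3ccc(OCCCN(C)C)nc3)cc12)c1ccn(C)n1`: 7 uL/min

Both compounds were tested in an ADME assay on cells (Hepatocyte, Rattus norvegicus) for metabolic stability, read by HPLC, with a stated time of 30 min, tested at 1 uM; on this read-out lower numbers stand for slow clearance and higher numbers for fast clearance. Of the two numbers, compound 2 gives the lower one with 7 uL/min, while compound 1 gives 18 uL/min, a gap that lies beyond the usual scatter of this assay. Compound 1 and compound 2 differ in more than one place, so their two values alone say nothing about any single change.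

Compound 3, `Cc1cn(C)nc1[C@H](C)Nc1c(C(N)=O)nnc2ccc(-c3ccc(OCCCN(C)C)nc3)cc12`, has not yet been measured. It is built from compound 2 by one change: methyl in place of hydrogen on an aromatic carbon. Among the measured compounds shown here, the same 1,4-dimethyl-1H-pyrazol-3-yl group is present in compound 1, but there it sits together with a different group on the other end of the shared core, so no pair of measured compounds isolates this change.

A step from compound 2 to compound 3 of a 1.4-fold higher number from compound 2 to compound 3 (0.15 log units; within the scatter) is expected in this assay, a rise that stays within the scatter. Compound 3 is therefore estimated at 10 uL/min, with a range of 5 uL/min to 20 uL/min.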

Compound 3, intrinsic clearance in a liver preparation (reported as CLH), per the amount of preparation that the assay uses: 12 uL/min
Estimate against measurement, compound 3: 1.2-fold (0.08 log units) below; low and high end bracket the measured number.
By their numbers in this assay, from the lowest: compounds 2, 3 and 1 (each within the scatter of the next, the first and the last beyond it).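

In this assay, the pair of compound 2 and compound 3 isolates methyl in place of hydrogen on an aromatic carbon of the five-membered aromatic ring, and it gives a 1.7-fold higher number from compound 2 to compound 3 (0.23 log units; within the scatter) as its step, so this read-out does not separate the two compounds at this position. Compound 3 also shares the 1,4-dimethyl-1H-pyrazol-3-yl group with compound 1, which isolates a second change, 3-(dimethylamino)propoxy in place of methoxymethyl on an aromatic carbon, with a 1.5-fold lower number from compound 1 to compound 3 (0.18 log units; within the scatter) as its step, and this change is not resolved either. No information at hand bears on the reasons for these numbers.

From the compounds shown here alone, it remains open whether a larger group on the same aromatic carbon, such as ethyl or cyclopropyl, or a single chlorine atom, would give a step beyond the scatter, and whether the methyl step would look the same with methoxymethyl at the other end of the shared core. Also open, going by these compounds, is how the chain itself reads on this assay, for example with a longer chain or with a morpholine in place of the dimethylamino group.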